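Swapping a Sulfonyl Amide Tail for an Aminoethanol Arm

The source may report more compounds than this note shows. Statements on the series, on what has been measured and on what is new or still open speak of the compounds shown alone.

Three measured compounds share one core: compound 1, `O=c1n(Cc2nc3ccc(Cl)cn3c2CCCCO)c2cnccc2n1C1CC1`, compound 2, `O=c1n(Cc2nc3cc(F)ccn3c2CCCCO)c2cnccc2n1C1CC1`, and compound 3, `CS(=O)(=O)CCNC(=O)c1c(Cn2c(=O)n(C3CC3)c3ccncc32)nc2cc(Cl)ccn12`. In an ADME assay on HEp-2 cells (Homo sapiens) for cytotoxicity, read by CCK-8 assay, with a stated time of 6 days (on this read-out lower numbers stand for higher toxicity in this test and higher numbers for lower toxicity in this test), compound 1 gives > 100000 nM, which is a limit of the assay rather than a number. In this assay compound 2 gives > 100000 nM, again a limit. In this assay compound 3 gives > 100000 nM, also a limit. Compound 3 thus sits at the limit of > 100000 nM in this assay, at which 3 of the 3 values shown sit. Among the compounds with values here, no step between measured compounds is available. Compound 4, `O=c1n(Cc2nc3cc(Cl)ccn3c2CNCCO)c2cnccc2n1C1CC1`, differs from compound 3 by ((2-hydroxyethyl)amino)methyl in place of (2-(methylsulfonyl)ethyl)carbamoyl on an aromatic carbon. The step that the limit leaves unreadable from compound 3 to compound 4 is expected to be none beyond the scatter. Compound 4 is therefore expected at 150000 nM, within a range from 50000 nM to 500000 nM.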

Compound 4, half-maximal cytotoxic concentration: > 100000 nM
Compound 4 was reported as a limit (the forecaster's own chance of this, stated with the estimate: 80%); the middle value lies beyond the limit too.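

The values of compound 3 and compound 4 are both limits in this assay, so no step between them can be read: the limit of > 100000 nM in this assay, at which 4 of the 4 values shown sit.

The compounds shown leave open how the swapped side chain affects cytotoxicity, since none gives a measured number in this assay.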